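Swapping the naphthyl amide cap for a cyanopyridine

The compounds below may be only part of what the source reports. "The series", "measured", "known", "first", "only" and "open" are said of these compounds alone.

Measured so far:
- compound 1 `COC(=O)c1scc(-c2ccc(NC(=O)c3ccc4ccccc4c3)cc2)c1OC`: 19500 nM
- compound 2 `COC(=O)c1scc(-c2ccc(NC(=O)c3ccc(F)c(Cl)n3)cc2)c1OC`: 10300 nM

Two compounds share one core, an aryl amide built on a thiophene ester, and differ only in the ring attached to the carbonyl carbon. In a functional assay on HepG2 cells (Homo sapiens) for antiproliferative activity, read by MTT assay, with a stated time of 24 h (a lower number here means a stronger inhibitor, a higher number a weaker inhibitor), compound 1 gives 19500 nM, and compound 2 gives 10300 nM in this assay. Compound 1 stands alongside compound 2, with the two numbers inside the usual scatter of each other; the step of a 1.9-fold lower number from compound 1 to compound 2 (0.28 log units; within the scatter) is the only one known.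

Compound 3 `COC(=O)c1scc(-c2ccc(NC(=O)c3ccc(C#N)nc3)cc2)c1OC` has not been measured. It differs from compound 1 by 6-cyanopyridin-3-yl in place of naphthalen-2-yl on a carbonyl carbon. This resembles the change from compound 1 to compound 2, where a naphthalen-2-yl was again replaced by a small nitrogen-containing ring, and that step stayed within the scatter. For the measured compounds named here, the single relevant step therefore points to no change beyond the scatter, perhaps a slightly lower number.

For compound 3 a value around 12000 nM is expected, between 5000 nM and 30000 nM, so that the expected step is a 1.6-fold lower number from compound 1 to compound 3 (0.21 log units; within the scatter).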

Compound 3, half-maximal inhibitory concentration: 22500 nM
For compound 3 the middle estimate is 1.9-fold (0.27 log units) below the measured one, within the range that was stated.
By their numbers in this assay, from the lowest: compounds 2, 1 and 3 (each within the scatter of the next, the first and the last beyond it).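

In this assay, the step of a 1.2-fold higher number from compound 1 to compound 3 (0.06 log units; within the scatter) shows that this position on a carbonyl carbon accepts a swap of the two fused carbon rings of naphthalen-2-yl for the single nitrile-bearing ring of 6-cyanopyridin-3-yl without a change beyond the scatter. The new comparison between two nitrogen-containing rings does separate them, though only modestly: the step of a 2.2-fold higher number from compound 2 to compound 3 (0.34 log units; beyond the scatter) shows that the ring's substituents and point of attachment, taken together, can move the number, so these two rings cannot be treated as interchangeable. No measurement is available that bears on the reason for this difference.

Going by these compounds, the step from 6-chloro-5-fluoropyridin-2-yl to 6-cyanopyridin-3-yl changes the chlorine, the fluorine, the nitrile and the point of attachment at once, so the share of each remains open. Also open, on these data alone, is whether a non-aromatic group on this carbonyl carbon, such as a ring bearing an amine, a carboxylic acid or a longer alkyl chain, would move the number further than these rings do.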